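Fluorine on the Methoxyphenyl Ring: Cytotoxicity Outlook

This account rests on a few compounds, and the source may have more. Where it says the series, first, only, none or still open, it means among the compounds named here.

The measured compounds:
Compound 1, `CC(=O)Nc1cccc(-c2ccc(C(=O)N(Cc3cccc(OCCCCCC(=O)O)c3)C(C)C)cc2)c1`, gives > 26000 nM in an ADME assay on BJ cells (Homo sapiens) for cytotoxicity, read by CellTiter-Glo and resazurin assay, with a stated time of 72 h; on this read-out lower numbers stand for an effect already at smaller amounts and higher numbers for an effect only at larger amounts of compound.
Compound 2, `CC(C)N(Cc1cccc(OCCCCCC(=O)O)c1)C(=O)c1ccc(-c2cccc(Oc3ccccc3)c2)cc1`, gives > 18700 nM.
Compound 3, `COc1cccc(-c2ccc(C(=O)N(Cc3cccc(OCCCCCC(=O)O)c3)C(C)C)cc2)c1`, gives > 20900 nM.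

Each of these three values is a limit of the assay rather than a number: the cytotoxicity read-out did not reach its half-maximal point within the tested amounts. Compound 3 therefore stands, like the other two, at a limit, and its exact position cannot be told from the data. The steps between the measured compounds, a step that the two limits leave unreadable from compound 1 to compound 2, a step that the two limits leave unreadable from compound 1 to compound 3 and a step that the two limits leave unreadable from compound 2 to compound 3, are all unreadable in size for the same reason, since both ends of each step are limits.

Compound 4, `COc1ccc(F)c(-c2ccc(C(=O)N(Cc3cccc(OCCCCCC(=O)O)c3)C(C)C)cc2)c1`, differs from compound 3 by fluoro in place of hydrogen on an aromatic carbon. Among the measured compounds shown here, none of the measured steps gives a readable size that bears on this change. What the data do show is that swapping acetamido, phenoxy or methoxy on the shared core left every compound at a limit, so no step beyond the scatter is expected here either. Compound 4 is expected to give 25000 nM in this assay, between 10000 nM and 60000 nM. This estimate means a step that the limit leaves unreadable from compound 3 to compound 4, expected to fall within the scatter.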

Compound 4, half-maximal effective concentration: > 26000 nM
Compound 4 ended at the assay's limit (the forecaster's own chance of this, stated with the estimate: 85%); middle value at least 1.0-fold (0.01 log units) from the limit.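

In this assay compound 4 gives > 26000 nM, which is a limit of the assay and not a number. With limits at both ends, its steps from compound 3 and from compound 1 cannot be read in size. The compounds shown leave open at what amount any of them reaches the half-maximal effect, and whether fluoro in place of hydrogen shifts that amount.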